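Moving the Ring Nitrogen: From Compound 3 to Compound 4

This account rests on a few compounds, and the source may have more. Where it says the series, first, only, none or still open, it means among the compounds named here.

Compound 1, `COc1cc2c(cc1OC)C(CC(=O)Nc1cccc(Cl)c1)CC2`: 28%
Compound 2, `COc1cc2c(cc1OC)C(CC(=O)Nc1ccc(Br)cc1)CC2`: 40%
Compound 3, `COc1cc2c(cc1OC)C(CC(=O)Nc1ccccn1)CC2`: 32%

Three compounds share one core and differ only in the ring attached to the amide nitrogen. In a functional assay on the whole organism (strain Wistar) for inhibition, with Rattus norvegicus as the target, read by paw edema, with a stated time of 2 h, at a dose of 100 mg/kg (a higher number here means more inhibition at the dose given (going by the name of the read-out), a lower number less inhibition), compound 3 gives 32%, the second highest of the three numbers. Its nearest neighbour is compound 1, with a number 4 percentage points higher from compound 1 to compound 3 (within the scatter); its furthest is compound 2, with a number 8 percentage points lower from compound 2 to compound 3 (within the scatter). Both of these gaps lie within the usual scatter, so compound 3 cannot be ordered against either.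

Compound 4, `COc1cc2c(cc1OC)C(CC(=O)Nc1ccncc1)CC2`, is the next step: pyridin-4-yl in place of pyridin-2-yl on an amide-type nitrogen. Among the compounds with values here, no measured step swaps one pyridinyl ring for another, so the guide is indirect. Of the steps that change the ring on the amide nitrogen, only a number 12 percentage points higher from compound 1 to compound 2 (beyond the scatter) went beyond the scatter, and modestly; the two steps into compound 3 stayed within it. The expectation is therefore a step of no size beyond the scatter, no change at the digits printed from compound 3 to compound 4 (within the scatter). Compound 4 is estimated at 32%, within a range of 18% to 46%.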

Compound 4, a percentage reported as inhibition, in the whole organism at one dose (the size of the read-out at that dose, not a potency): 44%
Compound 4: the middle estimate sits 12 percentage points below what was measured; the range from low to high includes it.
By their numbers in this assay, from the lowest: compounds 1, 3, 2 and 4 (each within the scatter of the next, the first and the last beyond it).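

Moving the ring nitrogen, with the same atoms joined differently, gives a number 12 percentage points higher from compound 3 to compound 4 (beyond the scatter) in this assay and so is enough on its own to shift the result. Against the halogen-bearing rings, a number 16 percentage points higher from compound 1 to compound 4 (beyond the scatter) clears the scatter, while a number 4 percentage points higher from compound 2 to compound 4 (within the scatter) does not, so the pyridin-4-yl ring cannot be told apart from the 4-bromophenyl ring. On this amide nitrogen, then, a pyridine ring's result depends on where its nitrogen sits, at least for these two rings.

Still open, as far as these compounds go, is how pyridin-3-yl would compare, and whether adding an amino group or a methyl group to the pyridin-4-yl ring would keep the result. Nothing available explains why the place of the ring nitrogen matters here.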